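This account rests on a few compounds, and the source may have more. Where it says the series, first, only, none or still open, it means among the compounds named here.

In a toxicity assay (LMTK cells) for cytotoxicity, with Mus musculus as the target, read by MTT assay, with a stated time of 72 h (on this read-out higher numbers stand for weaker inhibition and lower numbers for stronger inhibition), compound 3 (`Cc1c(C)c2c(c(C)c1O)CCC(C)(C(=O)NC1CC(C)(C)N([O])C1(C)C)O2`) gives > 300000 nM as a limit of the assay, not a number. Compound 4 (`Cc1c(C)c2c(c(C)c1OC(=O)CCC(=O)O)CCC(C)(C(=O)NC1CC(C)(C)N([O])C1(C)C)O2`) differs from it by one change ((2-carboxyethyl)carbonyl in place of hydrogen on an oxygen on an aromatic ring): (2-carboxyethyl)carbonyl in place of hydrogen on an oxygen on an aromatic ring. Compound 1 (`Cc1c(C)c2c(c(C)c1OC(=O)CCC(=O)O)CCC(C)(C(=O)NC1CC(C)(C)N([O])C(C)(C)C1)O2`) carries that group and gives > 300000 nM as a limit too. Compound 2 (`Cc1c(C)c2c(c(C)c1O)CCC(C)(C(=O)NC1CC(C)(C)N([O])C(C)(C)C1)O2`) lacks it and gives 252000 nM as a true number. Taking the group off gave an at least 1.1-fold lower number from compound 1 to compound 2 (0.07 log units; that floor lies within the scatter) and is the only measured step that bears on this one. In this assay the expected change is thus a step that the limit leaves unreadable from compound 3 to compound 4 and no step beyond the scatter, with any drift expected toward weaker inhibition. For compound 4 the estimated value is 400000 nM with an expected range from 200000 nM to 1000000 nM and a high expected chance of another limit.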

Compound 4, half-maximal inhibitory concentration: > 300000 nM
Compound 4: no number, only a limit; the forecaster's own chance of this, stated with the estimate: 85%; the middle value is on the limit's open side.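

No new step can be read from compound 1 or compound 3 to compound 4 in this assay, because all three values are limits: the limit of > 300000 nM in this assay, at which 3 of the 4 values shown sit. Going by these compounds, how much the (2-carboxyethyl)carbonyl group or the different amide-nitrogen group changes the read-out remains open.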